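The source may report more compounds than this note shows. Statements on the series, on what has been measured and on what is new or still open speak of the compounds shown alone.

Compound 1 `COc1ccc(C2=C(c3cc(OC)c(OC)c(OC)c3)C(=O)C(O[SiH2]C(C)(C)C)C2)cc1OC(C)C` was tested in an ADME assay on HEK293 cells (Homo sapiens) for cytotoxicity, read by MTT assay, with a stated time of 72 h; a higher number here means a weaker inhibitor, a lower number a stronger inhibitor. Compound 1 gave only a limit there, > 100 ug/mL. Compound 3 `COc1ccc(C2=C(c3cc(OC)c(OC)c(OC)c3)C(=O)CC2O)cc1O` likewise returned a limit in this assay, > 100 ug/mL. Compound 2 `CC(=O)OC1C/C(=N/O)C(c2ccccc2)=C1c1ccccc1` gave a number in this assay, 92.3 ug/mL. Among the compounds with values here, compound 1 thus sits at the limit of > 100 ug/mL in this assay, at which 2 of the 3 values shown sit, with compound 3 beside it, and no step between measured compounds has been recorded. Compound 4 `COc1ccc(C2=C(c3cc(OC)c(OC)c(OC)c3)C(=O)C(O[SiH2]C(C)(C)C)C2)cc1` has not yet been measured in this assay. It differs from compound 1 by hydrogen in place of isopropoxy on an aromatic carbon. Within the data shown here, no measured pair shows what such a change does here, so the step expected is a number no higher from compound 1 to compound 4 (the limit leaves the size open), nothing beyond the scatter. Compound 4 is therefore estimated at 100 ug/mL in this assay, within a range from 50 ug/mL to 200 ug/mL, most likely reported again as a limit.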

Compound 4, half-maximal inhibitory concentration: > 100 ug/mL
Compound 4 ended at the assay's limit (the forecaster's own chance of this, stated with the estimate: 70%); the middle value sits exactly at the limit.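

Within the data shown here, compound 1 and compound 4 both end at a limit in this assay, so no step between them can be read: the limit of > 100 ug/mL in this assay, at which 3 of the 4 values shown sit. The compounds shown leave open what hydrogen in place of isopropoxy does to the half-maximal inhibitory concentration.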